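The source may report more compounds than this note shows. Statements on the series, on what has been measured and on what is new or still open speak of the compounds shown alone.

Measured so far in a functional assay on MDA-MB-231 cells (Homo sapiens) for antiproliferative activity, read by MTT assay, with stated times of 72 h and 4 h; on this read-out lower numbers stand for stronger inhibition and higher numbers for weaker inhibition:
- compound 1 `O=C(Nc1ccc(Cl)c(-c2nnc3c(Cl)cccn23)c1)c1ccc(F)cc1Cl` gives 75000 nM.
- compound 2 `O=C(Nc1ccc(Cl)c(-c2nnc3c(Cl)cccn23)c1)c1cccnc1` gives > 100000 nM, which is a limit of this assay rather than a number.

Within the data shown here, compound 2 thus stands at the weaker edge of the two values shown; the only measured step touching it, an at least 1.3-fold higher number from compound 1 to compound 2 (0.12 log units; that floor lies within the scatter), sits at the limit of > 100000 nM in this assay, at which 1 of the 2 values shown sits, and its floor lies within the scatter, so the gap between compound 1 and compound 2 is not established as real.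

Compound 3 `O=C(Nc1ccc(Cl)c(-c2nnc3c(Cl)cccn23)c1)c1cccc(Cl)c1` carries the change (3-chlorophenyl in place of pyridin-3-yl on a carbonyl carbon). Among the measured compounds shown here, the one step that bears on it runs the other way: from compound 1 to compound 2 a chlorinated phenyl gave way to pyridin-3-yl and the number rose at least to the limit. For the measured compounds named here, compound 3 restores a chlorinated phenyl, though not the same one as in compound 1, and no step between compound 1 and compound 3 is available. The expected step is therefore an at least 1.2-fold lower number from compound 2 to compound 3 (0.09 log units; that floor lies within the scatter), a return toward a measurable number rather than a strong gain. For compound 3 in this assay a value of 80000 nM is expected, with a range from 30000 nM to 200000 nM.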

Compound 3, half-maximal inhibitory concentration: 66100 nM
Compound 3: middle estimate off by 1.2-fold (0.08 log units), on the high side, and the stated range covers the measured number.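

Notes on the group on the carbonyl carbon, read in this assay: a second chlorinated phenyl now sits at this position, and the two such compounds cannot be told apart, with a 1.1-fold lower number from compound 1 to compound 3 (0.05 log units; within the scatter). Exchanging 2-chloro-4-fluorophenyl for 3-chlorophenyl therefore leaves the read-out unresolved, and the fluorine and the placing of the chlorine carry no visible consequence in this pair. Against pyridin-3-yl, both chlorinated phenyls give measurable numbers, but an at least 1.5-fold lower number from compound 2 to compound 3 (0.17 log units; that floor lies within the scatter) does not establish a real gap, and compound 2 stands only at a limit of the assay, not at a number: the limit of > 100000 nM in this assay, at which 1 of the 3 values shown sits.

Still open, from the compounds shown here alone, is whether the ring nitrogen or the chlorine accounts for the move from pyridin-3-yl to 3-chlorophenyl, since the two differ in both; a plain phenyl on the same carbonyl carbon would separate them. Also open, going by these compounds, is whether any group at this position reaches numbers clearly lower than those of compound 1 and compound 3, for instance a saturated cyclohexyl ring or a chain ending in an amine.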